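From Bromine to Fluorine: One Swap, One Expected Outcome

This account rests on a few compounds, and the source may have more. Where it says the series, first, only, none or still open, it means among the compounds named here.

Of the compounds shown here, three have so far been tested in a functional assay on MCF7 cells (Homo sapiens) for antiproliferative activity, read by MTT assay, with a stated time of 72 h; a lower number here means a stronger inhibitor, a higher number a weaker inhibitor. Compound 1, with the structure `O=C(COc1ccc(C(=O)/C=C/c2ccccc2Br)cc1)N[C@H]1CCOC1=O`, is the only one to give a definite number: in this assay compound 1 gives 15300 nM. Compound 2, with the structure `Cc1ccc(C(C)C)c(OCCSC(=S)N[C@H]2CCOC2=O)c1`, reaches only the limit of the assay, recorded as > 64000 nM. Compound 3, with the structure `O=C1OCC[C@@H]1NC(=S)SCCOc1ccccc1[N+](=O)[O-]`, likewise stops at a limit, > 64000 nM. Compound 1 therefore stands alone as the measured point, while the others sit at the limit of > 64000 nM in this assay, at which 2 of the 3 values shown sit.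

Compound 4, with the structure `O=C(COc1ccc(C(=O)/C=C/c2cccc(F)c2)cc1)N[C@H]1CCOC1=O`, has not yet been measured. It keeps the shared core of compound 1 and differs in one place: 3-fluorophenyl in place of 2-bromophenyl on a double-bonded chain carbon bound to a double-bonded chain carbon. Among the measured compounds shown here, no pair of measured compounds differs by a single change, so there is no measured step to lean on; what is known is only that compound 1 is a weak inhibitor at 15300 nM.

With one halogen exchanged for another, the step from compound 1 to compound 4 is expected to be small and of no sure direction, likely within ordinary scatter, so a 1.2-fold higher number from compound 1 to compound 4 (0.07 log units; within the scatter) is the expected change. Compound 4 is estimated to come out at 18000 nM, within a range of 6000 nM to 50000 nM.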

Compound 4, half-maximal inhibitory concentration: > 64000 nM
Compound 4: only a limit was reported (the forecaster's own chance of this, stated with the estimate: 15%); at least 3.5-fold (0.55 log units) between middle value and limit.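

Within this assay, the exchange of 2-bromophenyl for 3-fluorophenyl on a double-bonded chain carbon bound to a double-bonded chain carbon proves to be more than a minor swap, giving an at least 4.1-fold higher number from compound 1 to compound 4 (0.62 log units; beyond the scatter). Among the compounds shown here, this is the first single-place comparison in the set, and it shows that the shared core alone does not secure a measurable result, since the weak activity of compound 1 is lost when only this aromatic group changes. Compound 4 gives > 64000 nM, which is a limit and not a number, so the step marks only the smallest possible difference, and compound 4 now sits with the other compounds at that same limit: the limit of > 64000 nM in this assay, at which 3 of the 4 values shown sit.

For the compounds shown here, the single change alters both the halogen and its place on the ring, so these compounds cannot show whether the bromine itself, its location, or both matter to the result of compound 1. Also open, from the compounds shown here alone, is how the series would respond to a plain phenyl group, or to a phenyl ring carrying chlorine or an amine, in this same position on the chain.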